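Trichlorophenyl Variant of a Series Sitting at the Limit

The compounds below may be only part of what the source reports. "The series", "measured", "known", "first", "only" and "open" are said of these compounds alone.

compound 1 `N#CC1=C(N)Oc2c(N)cc3nc4ccccc4nc3c2C12C(=O)N(Cc1cnnn1-c1ccc(F)cc1)c1ccccc12` — > 50000 nM
compound 2 `CCc1cccc(C)c1-n1nncc1CN1C(=O)C2(C(C#N)=C(N)Oc3c(N)cc4nc5ccccc5nc4c32)c2ccccc21` — > 50000 nM
compound 3 `Cc1cc(C)cc(-n2nncc2CN2C(=O)C3(C(C#N)=C(N)Oc4c(N)cc5nc6ccccc6nc5c43)c3ccccc32)c1` — > 50000 nM

In an ADME assay on HUVEC cells (Homo sapiens) for antiproliferative activity, read by MTT assay, with a stated time of 48 h (on this read-out lower numbers stand for stronger inhibition and higher numbers for weaker inhibition), compound 1 gives > 50000 nM, which is a limit of the assay and not a number. Compound 2 gives > 50000 nM, likewise a limit. Compound 3 gives > 50000 nM, again a limit. All three values therefore sit at the limit of > 50000 nM in this assay, at which 3 of the 3 values shown sit, and compound 3 stands there together with the other two, with no number of its own. The changes among them, a step that the two limits leave unreadable from compound 1 to compound 2, a step that the two limits leave unreadable from compound 1 to compound 3 and a step that the two limits leave unreadable from compound 2 to compound 3, are consequently unreadable in size and direction: three different groups on the aromatic nitrogen have all left the read-out at the same limit.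

Compound 4 `N#CC1=C(N)Oc2c(N)cc3nc4ccccc4nc3c2C12C(=O)N(Cc1cnnn1-c1c(Cl)cc(Cl)cc1Cl)c1ccccc12` continues this series with 2,4,6-trichlorophenyl in place of 3,5-dimethylphenyl on an aromatic nitrogen. The measured steps that bear on it are exactly these three unreadable ones, and none of them shows any group on that nitrogen moving the value away from the limit. Compound 4 is therefore expected to behave like compound 3, with a step that the limit leaves unreadable from compound 3 to compound 4 that stays within the scatter, and its value in this assay is estimated at 80000 nM, with a range from 30000 nM to 300000 nM, most likely reported again only as a limit.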

Compound 4, half-maximal inhibitory concentration: 18300 nM
The estimate for compound 4 lay 4.4-fold (0.64 log units) above the measured number, outside the stated range (below it).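

In this assay compound 4 gives 18300 nM, a real number. This position on the aromatic nitrogen can therefore carry a change that moves the read-out off the limit, which the earlier compounds could not show: the limit of > 50000 nM in this assay, at which 3 of the 4 values shown sit.

As far as these compounds go, the 2,4,6-trichlorophenyl group stands apart from each of the other three groups, with an at least 2.7-fold lower number from compound 3 to compound 4 (0.43 log units; beyond the scatter), an at least 2.7-fold lower number from compound 2 to compound 4 (0.43 log units; beyond the scatter) and an at least 2.7-fold lower number from compound 1 to compound 4 (0.43 log units; beyond the scatter), and each of these steps gives only the smallest size the limit allows, so the full size stays unknown. The steps among compound 1, compound 2 and compound 3 still cannot be read, and compound 4 is the only one of the four whose phenyl ring carries chlorine, so the series now has one measured point and no trend.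

What the compounds shown leave open is whether all three chlorine atoms are needed, or whether a phenyl ring with a single chlorine, a bromine or a methoxy group on that nitrogen would also leave the limit. They also leave open how far below compound 4 any group at this position could go in this assay.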